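This account rests on a few compounds, and the source may have more. Where it says the series, first, only, none or still open, it means among the compounds named here.

Among the measured compounds shown here, compound 2 `Cc1cc(C)c(S(=O)(=O)N[C@@H](CNC(=O)CO[C@@H]2C[C@@H](CNc3ccccn3)N(C(=O)CC(C)(C)C)C2)C(=O)O)c(C)c1` gives 6 nM in an assay on a protein complex for inhibition of integrin alpha-5/beta-1 (Homo sapiens), read by ELISA (on this read-out lower numbers stand for stronger inhibition and higher numbers for weaker inhibition), the lowest of the two numbers known; its nearest neighbour is compound 1 `Cc1cc(C)c(S(=O)(=O)N[C@@H](CNC(=O)CO[C@@H]2C[C@@H](CNc3ccccn3)N(C(=O)CCc3ccccc3)C2)C(=O)O)c(C)c1`, which in this assay gives 25 nM, and the step of a 4.2-fold lower number from compound 1 to compound 2 (0.62 log units; beyond the scatter) is the only one measured at this position. Compound 3 `COC(=O)N1C[C@H](OCC(=O)NC[C@H](NS(=O)(=O)c2c(C)cc(C)cc2C)C(=O)O)C[C@H]1CNc1ccccn1` carries methoxy in place of neopentyl on a carbonyl carbon, again on the carbonyl attached to the ring nitrogen. For the measured compounds named here, no measured step covers this exchange; the one step at this place was modest, so compound 3 is expected to stay near compound 2, with a step of a 2.0-fold higher number from compound 2 to compound 3 (0.30 log units; within the scatter), estimated at 12 nM (range 4 nM to 40 nM).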

Compound 3, half-maximal inhibitory concentration: 15 nM
Compound 3: middle estimate off by 1.3-fold (0.10 log units), on the low side, within the range that was stated.
By their numbers in this assay, from the lowest: compound 2; then compounds 3 and 1 (each within the scatter of the next).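

In this assay, among the compounds shown here, the exchange of neopentyl for methoxy on the carbonyl carbon gives a 2.5-fold higher number from compound 2 to compound 3 (0.40 log units; beyond the scatter) and so provides a first reading at this position for a group joined through oxygen. Methoxy in place of phenethyl gives a 1.7-fold lower number from compound 1 to compound 3 (0.22 log units; within the scatter) and leaves neopentyl as the only one of the three groups set apart beyond the scatter. No evidence here bears on why these groups differ. Still open, from the compounds shown here alone, is whether tert-butoxy on this carbonyl carbon would come closer to compound 2, and how an amine there would read.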